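Fluorophenyl for tolyl on a shared antiproliferative core

The source may report more compounds than this note shows. Statements on the series, on what has been measured and on what is new or still open speak of the compounds shown alone.

Compound 1 `CCC1=C(O)c2c(oc(-c3ccc(C)cc3)cc2=O)C(CC)(CC)C1=O` gives 39.2 uM in a functional assay on KB cells (Homo sapiens) for antiproliferative activity, read by sulforhodamine B assay, with a stated time of 3 days; a lower number here means that less compound is needed, a higher number that more compound is needed for the effect. Compound 3 `CCC1=C(O)c2c(oc(-c3ccccc3C(F)(F)F)cc2=O)C(CC)(CC)C1=O` gives 45.6 uM in this assay, a number within the usual scatter of compound 1. Compound 2 `CCCc1ccc(-c2cc(=O)c3c(o2)C(CC)(CC)C(=O)C(CC)=C3O)cc1` yields only a limit of the assay, > 53 uM, as noted (the limit of > 53 uM in this assay, at which 1 of the 3 values shown sits). Going by the values given here, the one measured step, an at least 1.3-fold higher number from compound 1 to compound 2 (0.13 log units; that floor lies within the scatter), is a different change and gives little guidance here. Compound 4 `CCC1=C(O)c2c(oc(-c3ccccc3F)cc2=O)C(CC)(CC)C1=O` is obtained from compound 1 through (2-fluorophenyl in place of 4-methylphenyl on an aromatic carbon). Compound 3 shows that another change on this aryl group left the number within scatter of compound 1, so no step beyond the scatter is expected for compound 4. Compound 4 is estimated at 42 uM, between 24 uM and 75 uM. This estimate means the step of a 1.1-fold higher number from compound 1 to compound 4 (0.03 log units; within the scatter).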

Compound 4, concentration for half-maximal effect: > 56.2 uM
Compound 4 ended at the assay's limit; the forecaster's own chance of this, stated with the estimate: 25%; middle value at least 1.3-fold (0.12 log units) away from the limit.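

In this assay, compound 4 gives only a limit of the assay: the limit of > 56.2 uM in this assay, at which 1 of the 4 values shown sits. Setting 2-fluorophenyl in place of 4-methylphenyl gives an at least 1.4-fold higher number from compound 1 to compound 4 (0.15 log units; that floor lies within the scatter), and fluoro in place of trifluoromethyl gives an at least 1.2-fold higher number from compound 3 to compound 4 (0.09 log units; that floor lies within the scatter), so neither floor shows a step beyond the scatter. The step between the two limits, from compound 2 to compound 4, cannot be read. The compounds shown leave open whether any change on this aryl group moves the number beyond the scatter from compound 1. From the compounds shown here alone, what an amine or a carboxylic acid on this aryl group would do also stays open.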